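Swapping the terminal amide for a hydroxamic acid

The source may report more compounds than this note shows. Statements on the series, on what has been measured and on what is new or still open speak of the compounds shown alone.

compound 1 `CNC(=O)CCCCCCCn1nc(-c2ccc3oc(N)nc3c2)c2c(N)ncnc21` — 3640 nM
compound 2 `Nc1ncnc2c1c(-c1cnc3[nH]ccc3c1)nn2CCCCCCC(=O)NO` — 10300 nM
compound 3 `Nc1nc2cc(-c3nn(CCC(=O)NO)c4ncnc(N)c34)ccc2o1` — > 150000 nM (a limit)

In a functional assay on HepG2 cells (Homo sapiens) for inhibition, read by MTT assay, with a stated time of 72 h (on this read-out higher numbers stand for weaker inhibition and lower numbers for stronger inhibition), compound 1 gives 3640 nM, the lowest of the two numbers measured, while compound 2 gives the higher 10300 nM. Compound 3 sits at a limit of this assay, > 150000 nM. Among the compounds with values here, the single step measured in one place, an at least 41-fold higher number from compound 1 to compound 3 (1.61 log units; beyond the scatter), is large and ends at the limit (the limit of > 150000 nM in this assay, at which 1 of the 3 values shown sits). Compound 4 `Nc1nc2cc(-c3nn(CCCCCCCCC(=O)NO)c4ncnc(N)c34)ccc2o1` differs from compound 1 by (hydroxycarbamoyl)methyl in place of methylcarbamoyl on a saturated chain carbon, seven bonds along the chain from an aromatic nitrogen. Compound 4 keeps the long chain that compound 3 lacks, so the large step is not expected to repeat; compound 2, carrying the same hydroxycarbamoyl end on a long chain, gives 10300 nM and points to a modest rise. Compound 4 is therefore expected to give 8000 nM, between 3000 nM and 25000 nM, a step of a 2.2-fold higher number from compound 1 to compound 4 (0.34 log units; beyond the scatter).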

Compound 4, half-maximal inhibitory concentration: 2610 nM
Compound 4: middle estimate off by 3.1-fold (0.49 log units), on the high side; measured number outside the range, below it.
By their numbers in this assay, from the lowest: compounds 4 and 1 (each within the scatter of the next); then compound 2. At a limit, above all of these: compound 3.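

With the long chain kept, (hydroxycarbamoyl)methyl in place of methylcarbamoyl brings no real change in this assay: a 1.4-fold lower number from compound 1 to compound 4 (0.14 log units; within the scatter). On the same hydroxycarbamoyl end, 6-(hydroxycarbamoyl)hexyl in place of hydroxycarbamoyl gives an at least 57-fold lower number from compound 3 to compound 4 (1.75 log units; beyond the scatter), so the large earlier step goes with the short chain and not with the hydroxycarbamoyl end. Compound 3 remains a limit and not a number: the limit of > 150000 nM in this assay, at which 1 of the 4 values shown sits.

Still open, going by these compounds, is how a longer chain or one of middle length would read. So is whether a carboxylic acid or an amine at the chain end would match the hydroxycarbamoyl end.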